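Inverting the single stereocentre: working notes

The compounds below may be only part of what the source reports. "The series", "measured", "known", "first", "only" and "open" are said of these compounds alone.

In an ADME assay on MDCK cells (Canis lupus familiaris) for cytotoxicity (on this read-out lower numbers stand for higher toxicity in this test and higher numbers for lower toxicity in this test), compound 3 `CC(=O)Nc1ccc2oc(-c3ccnc(C(=O)N4CCN([C@@H](c5ccc(F)cc5)c5nnn(C)n5)CC4)c3)nc2c1` gives > 200000 nM as a limit, not a number. Compound 1 `CC(=O)Nc1ccc2oc(-c3ccnc(C(=O)N4CCC5(CC4)CN(C(c4ccccc4)c4nnn(C)n4)C5)c3)nc2c1` gives > 50000 nM and this too is a limit. Compound 2 `CC(=O)Nc1ccc2oc(-c3ccnc(C(=O)N4CCN(C(c5ccc(F)cc5)c5nnn(C)n5)CC4)c3)nc2c1` gives > 50000 nM and this is likewise a limit. The change to compound 4 `CC(=O)Nc1ccc2oc(-c3ccnc(C(=O)N4CCN([C@H](c5ccc(F)cc5)c5nnn(C)n5)CC4)c3)nc2c1` is this: the two compounds have the same atoms and bonds and differ only in configuration as drawn: 1 of 1 stereo elements differ; a stereocentre at a saturated chain carbon is drawn S in compound 3 and R in compound 4 with nothing else touched. Among the compounds with values here, the one measured step on configuration is a step that the two limits leave unreadable from compound 2 to compound 3 and offers no size to carry over. Within the data shown here, with every value so far a limit, no step beyond the scatter is expected in this assay for this inversion. The estimated step is a number no higher from compound 3 to compound 4 (the limit leaves the size open) on that basis. For compound 4 the expected value is 200000 nM within an estimated range from 50000 nM to 400000 nM and most likely reported as a limit.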

Compound 4, half-maximal cytotoxic concentration: > 200000 nM
Compound 4: a limit, no number (the forecaster's own chance of this, stated with the estimate: 90%); the middle value lies on the limit itself.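

In this assay compound 3 and compound 4 both give limits rather than numbers, so no step can be read between them or from compound 2 to either. On these data alone, whether the S and R configurations differ in this assay remains open.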